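From Dimethylamino to Amino on a Shared Core

The source may hold more compounds than are shown below. What is called first, only, known or untested is meant among the compounds shown, and "the series" means these compounds.

Compound 1 `CCCCCCCCCCC(CCO)n1cnc2c(OC)ncnc21` and compound 2 `CCCCCCCCCCC(CCO)n1cnc2c(N(C)C)ncnc21` differ in a single group on the same core. In a functional assay on HCT-116 cells (Homo sapiens) for antiproliferative activity, read by MTT assay, with a stated time of 48 h (a higher number here means a weaker inhibitor, a lower number a stronger inhibitor), compound 1 gives 7530 nM and compound 2 gives 5490 nM. These two values lie within the scatter of each other, so compound 2 has no real edge, even though it carries the lower number.

The next compound is compound 3 `CCCCCCCCCCC(CCO)n1cnc2c(N)ncnc21`, which has not yet been measured. Its change from compound 2 is amino in place of dimethylamino on an aromatic carbon, with amino in place of dimethylamino on an aromatic carbon. Among the compounds with values here, only one measured step bears on this change, as it also swaps the group on that carbon: a 1.4-fold lower number from compound 1 to compound 2 (0.14 log units; within the scatter). Within the data shown here, one small step is thin evidence, and no measured compound yet carries the amino group. It gives no reason to expect a clear shift in either direction in this assay.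

The expected size of the change is a 1.1-fold lower number from compound 2 to compound 3 (0.04 log units; within the scatter), which would not go beyond the scatter. Compound 3 is expected at about 5000 nM, with an estimated range from 2200 nM to 11000 nM.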

Compound 3, half-maximal inhibitory concentration: 2590 nM
Compound 3: middle estimate off by 1.9-fold (0.29 log units), on the high side; low and high end bracket the measured number.
By their numbers in this assay, from the lowest: compound 3; then compounds 2 and 1 (each within the scatter of the next).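

Within the data shown here, replacing dimethylamino with amino at this position produces the first change beyond the scatter in this assay, with a 2.1-fold lower number from compound 2 to compound 3 (0.33 log units; beyond the scatter) and a somewhat larger difference against the methoxy compound, with a 2.9-fold lower number from compound 1 to compound 3 (0.46 log units; beyond the scatter). Both steps are modest, but together they make compound 3 the most potent of the three compounds, whereas compound 1 and compound 2 could not be separated from each other. Going from dimethylamino to amino removes two carbon atoms and adds one hydrogen-bond donor, but no measurement here shows which of these differences, if either, accounts for the lower number, and no independent data offer an explanation.

The compounds shown leave open where a methylamino group, with a single methyl on the nitrogen, would fall relative to amino and dimethylamino, and therefore whether the lower number needs both methyl groups to be gone. They also leave open whether the step from dimethylamino to amino would be of similar size if a shorter alkyl chain replaced the long chain on the shared core.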